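The source may hold more compounds than are shown below. What is called first, only, known or untested is meant among the compounds shown, and "the series" means these compounds.

Measured in an ADME assay on HEK293 cells (Homo sapiens) for cytotoxicity, with a stated time of 72 h; a lower number here means that less compound is needed, a higher number that more compound is needed for the effect:
- Compound 1 `C=C[C@@](C)(/C=C/c1ccc(OCc2ccccc2)cc1)CCC=C(C)C`: > 36600 nM (a limit)
- Compound 2 `C=C[C@@](C)(/C=C/c1ccc(-c2ccc(Cl)cc2)cc1)CCC=C(C)C`: > 36600 nM (a limit)

Neither compound has a number in this assay, and compound 2 stands only at its limit of > 36600 nM. The evidence amounts to the limit of > 36600 nM in this assay, at which 2 of the 2 values shown sit. Compound 3 `C=C[C@@](C)(/C=C/c1ccc(-c2ccc(Cl)c(Cl)c2)cc1)CCC=C(C)C` changes compound 2 by one substitution, (chloro in place of hydrogen on an aromatic carbon), with chloro in place of hydrogen on an aromatic carbon, turning 4-chlorophenyl into 3,4-dichlorophenyl. Among the compounds with values here, the only measured step bearing on this is a step that the two limits leave unreadable from compound 1 to compound 2, where 4-chlorophenyl replaced benzyloxy on an aromatic carbon, and it gives no size to carry over. No step beyond the usual scatter is therefore expected in this assay, in either direction, and another limit is the likeliest report. The expected step is a step that the limit leaves unreadable from compound 2 to compound 3. Compound 3 is estimated at 38000 nM, with an expected range from 18000 nM to 80000 nM.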

Compound 3, half-maximal effective concentration: > 36600 nM
Compound 3: no number, only a limit; the forecaster's own chance of this, stated with the estimate: 70%; the middle value lies beyond the limit too.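

No step can be read among compound 1, compound 2 and compound 3 in this assay: each is reported only as a limit. The compounds shown leave open what concentration any of them needs for the effect, and whether the added chloro shifts it.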